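Extending the Polyamine Branch of Compound 2

The source may report more compounds than this note shows. Statements on the series, on what has been measured and on what is new or still open speak of the compounds shown alone.

Measured in a functional assay on J774.1 cells (Mus musculus) for inhibition, read by Griess assay; a lower number here means a stronger inhibitor, a higher number a weaker inhibitor:
Compound 1 `CCCCCCCCCCCCS(=O)(=O)NCCCNCCCNCCCCNCCCNCCCNS(=O)(=O)CCCCCCCCCCCC`: 5000 nM
Compound 2 `CCCCCCCCCCCCS(=O)(=O)NCCCN(CCCNCCCCNCCCN)CCCNS(=O)(=O)CCCCCCCCCCCC`: 2270 nM
Compound 3 `CCCCCCCCS(=O)(=O)NCCCN(CCCNCCCNCCCCNCCCN)CCCNS(=O)(=O)CCCCCCCC`: 320 nM

Compound 2, at 2270 nM, stands second highest of the three numbers, with both neighbours beyond the scatter. Compound 4 `CCCCCCCCCCCCS(=O)(=O)NCCCN(CCCNCCCNCCCCNCCCN)CCCNS(=O)(=O)CCCCCCCCCCCC` remains unmeasured. Relative to compound 2, it carries (4-((3-aminopropyl)amino)butyl)amino in place of ((3-aminopropyl)amino)methyl on a saturated chain carbon, three bonds along the chain from an amine nitrogen. Among the compounds with values here, no measured pair isolates this change, so the expectation rests loosely on compound 3 at 320 nM. The step expected in this assay is towards a lower number, estimated as a 2.3-fold lower number from compound 2 to compound 4 (0.36 log units; beyond the scatter). For compound 4 the estimated value is 1000 nM, with an expected range of 300 nM to 3000 nM.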

Compound 4, half-maximal inhibitory concentration: 510 nM
Compound 4: middle estimate off by 2.0-fold (0.29 log units), on the high side; measured number inside the range.
By their numbers in this assay, from the lowest: compounds 3 and 4 (each within the scatter of the next); then compound 2; then compound 1.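

In this assay, within the data shown here, putting (4-((3-aminopropyl)amino)butyl)amino in place of ((3-aminopropyl)amino)methyl gives a 4.5-fold lower number from compound 2 to compound 4 (0.65 log units; beyond the scatter) at this position, the first direct reading of a change to this branch. The place on a saturated chain carbon, three bonds along the chain from an amine nitrogen, therefore responds to this exchange while the dodecyl sulfonamide ends stay the same. From the compounds shown here alone, whether the extra amine nitrogen or the extra length carries the step stays open, and an all-carbon chain of the same length or an acetamide on the terminal amine would separate the two. Nothing available explains the step.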